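The compounds below may be only part of what the source reports. "The series", "measured", "known", "first", "only" and "open" are said of these compounds alone.

Of the compounds shown here, three have been tested for how much of each survives incubation with liver enzymes. Compound 1 `CC(=O)Nc1cc(-c2ccc(OC[C@@H](N)CC(C)C)c(C)c2)ccn1` gives 91% in an ADME assay on microsomes from liver (Homo sapiens) for metabolic stability, read by LC-MS, using NADPH, with a stated time of 10 min, tested at 0.5 uM; a lower number here means that less of the compound is left, a higher number that more of the compound is left. Compound 3 `CC(=O)Nc1cc(-c2ccc(OC[C@@H](N)CC(C)C)c(Cl)c2)ccn1` gives 89% in this assay. The two differ by one change, (methyl in place of chloro on an aromatic carbon), and the measured step is a number 2 percentage points higher from compound 3 to compound 1 (within the scatter). Compound 2 `COC(=O)Nc1cc(-c2cc(Cl)c(OC[C@@](C)(N)CC(C)C)cn2)ccn1` gives 96% in this assay; the difference between its core and that of compound 3 is not broken down here. Compound 4 `COC(=O)Nc1cc(-c2cc(C)c(OC[C@@](C)(N)CC(C)C)cn2)ccn1` is not yet measured. It differs from compound 2 by the same kind of change, (methyl in place of chloro on an aromatic carbon), though the place differs: the ring is a six-membered aromatic ring with 1 nitrogen rather than one of carbon only, the group ortho to it is a (2-amino-2,4-dimethylpentyl)oxy group rather than a (2-amino-4-methylpentyl)oxy group, and the carbon is opposite the ring nitrogen. Because a number 2 percentage points higher from compound 3 to compound 1 (within the scatter), a similarly small step is expected, no change at the digits printed from compound 2 to compound 4 (within the scatter). Compound 4 is therefore expected to give about 96% in this assay, likely between 88% and 100%.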

Compound 4, percent of the compound remaining: 100%
Estimate against measurement, compound 4: 4 percentage points below, and the stated range covers the measured number.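

In this assay, methyl in place of chloro gives a number 4 percentage points higher from compound 2 to compound 4 (within the scatter). Set beside the same change on the other core, the two steps agree: the same change on two cores in this assay, a number 2 percentage points higher (within the scatter) from compound 3 to compound 1 and a number 4 percentage points higher (within the scatter) from compound 2 to compound 4, 2 percentage points apart, within the scatter of two such steps This shows that the swap left the amount of compound remaining within the usual scatter on both cores, but it does not show that methyl truly raises that number, and two cores do not make a rule for the series.

The compounds shown leave open how other groups on this aromatic carbon, such as fluoro, methoxy or nitrile, would read. Also open, on these data alone, is whether the swap would stay this small on a core of which much less remains.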